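The source may hold more compounds than are shown below. What is called first, only, known or untested is meant among the compounds shown, and "the series" means these compounds.

Compound 1 `C=C(CC)C(=O)c1ccc(OCC(=O)Nc2ccc(C(=O)O)cc2)c(Cl)c1Cl` in a functional assay on CLL cells (Homo sapiens) for cytotoxicity, read by MTT assay, with a stated time of 48 h (a lower number here means that less compound is needed, a higher number that more compound is needed for the effect), gives 5000 nM, the highest of the two numbers recorded; compound 3 `C=C(CC)C(=O)c1ccc(OCC(=O)NCO[N+](=O)[O-])c(Cl)c1Cl` stands nearest with 4100 nM, a step of a 1.2-fold lower number from compound 1 to compound 3 (0.09 log units; within the scatter). Compound 2 `C=C(CC)C(=O)c1ccc(OCC(=O)NCC(=O)O)c(Cl)c1Cl` gives only a limit, > 25000 nM. The steps of an at least 5.0-fold higher number from compound 1 to compound 2 (0.69 log units; beyond the scatter) and an at least 6.0-fold lower number from compound 2 to compound 3 (0.78 log units; beyond the scatter) show that a carboxy-bearing group on the amide nitrogen gives the weaker result. Compound 4 `C=C(CC)C(=O)c1ccc(OCC(=O)Nc2ccc(/C=C/C(=O)NO)cc2)c(Cl)c1Cl` carries 2-(hydroxycarbamoyl)ethenyl in place of carboxy on an aromatic carbon. Going by the values given here, two steps bear on it: a 1.2-fold lower number from compound 1 to compound 3 (0.09 log units; within the scatter) stayed within the scatter when the carboxy-bearing group was exchanged, and an at least 6.0-fold lower number from compound 2 to compound 3 (0.78 log units; beyond the scatter) fell when carboxy gave way to nitrooxy. Compound 4 is therefore expected to show a small step lower, a 1.7-fold lower number from compound 1 to compound 4 (0.22 log units; within the scatter), estimated at 3000 nM with a range of 1000 nM to 9000 nM.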

Compound 4, half-maximal effective concentration: 2600 nM
For compound 4 the middle estimate is 1.2-fold (0.06 log units) above the measured one; low and high end bracket the measured number.
By their numbers in this assay, from the lowest: compounds 4, 3 and 1 (each within the scatter of the next). At a limit, above all of these: compound 2.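

Exchanging only the group on the aromatic carbon, para to a large group, while the six-membered aromatic ring stays in place, gives in this assay a step of a 1.9-fold lower number from compound 1 to compound 4 (0.28 log units; within the scatter). The earlier steps shown here replaced the whole group on the amide-type nitrogen, whereas this one shows that carboxy can give way to 2-(hydroxycarbamoyl)ethenyl at this place with the number staying within the scatter. Nothing measured here accounts for this result. From the compounds shown here alone, whether an amine or a longer chain at this aromatic carbon would move the number beyond the scatter stays open.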